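Iodo in Place of Chloro on an Amino Compound

This account rests on a few compounds, and the source may have more. Where it says the series, first, only, none or still open, it means among the compounds named here.

Compound 1 `C#C[C@@]1(O)[C@@H](CO)O[C@@H](n2cc(Cl)c3c(Cl)ccnc32)[C@@H]1O` gives 1300 nM
Compound 2 `C#C[C@@]1(O)[C@@H](CO)O[C@@H](n2cc(I)c3c(Cl)ccnc32)[C@@H]1O` gives 260 nM
Compound 3 `C#C[C@@]1(O)[C@@H](CO)O[C@@H](n2cc(Cl)c3c(N)ccnc32)[C@@H]1O` gives 5400 nM

In a functional assay on CCRF-CEM cells (Homo sapiens) for antiproliferative activity, read by cell counting, with a stated time of 72 h (on this read-out higher numbers stand for weaker inhibition and lower numbers for stronger inhibition), compound 3 gives 5400 nM and stands highest of the three, with a gap beyond the scatter to each of the others. Compound 4 `C#C[C@@]1(O)[C@@H](CO)O[C@@H](n2cc(I)c3c(N)ccnc32)[C@@H]1O` keeps the amino group of compound 3 but carries iodo in place of chloro on an aromatic carbon, and iodo in place of chloro on an aromatic carbon sums up that change.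

The same replacement has been measured once, as a 5.0-fold lower number from compound 1 to compound 2 (0.70 log units; beyond the scatter) in a pair without the amino group, and this is the closest guide. The other measured change, a 4.2-fold higher number from compound 1 to compound 3 (0.62 log units; beyond the scatter) with amino in place of chloro, shows what separates the two backgrounds. Among the measured compounds shown here, no measured pair shows whether the iodo step carries over unchanged to an amino compound, so a similar size towards a lower number is expected, with wide uncertainty.

The step is estimated as a 4.5-fold lower number from compound 3 to compound 4 (0.65 log units; beyond the scatter) and rests on that single pair. For compound 4 the estimated value is 1200 nM with 350 nM to 3800 nM as the expected range.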

Compound 4, half-maximal inhibitory concentration: 310 nM
Compound 4: the middle estimate sits 3.9-fold (0.59 log units) above what was measured; the whole stated range lies above it.
By their numbers in this assay, from the lowest: compounds 2 and 4 (each within the scatter of the next); then compound 1; then compound 3.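

In this assay, iodo in place of chloro gives a 17-fold lower number from compound 3 to compound 4 (1.24 log units; beyond the scatter), so the step on this aromatic carbon of the five-membered ring does not keep one size from core to core: the same change on two cores in this assay, a 5.0-fold lower number (0.70 log units; beyond the scatter) from compound 1 to compound 2 and a 17-fold lower number (1.24 log units; beyond the scatter) from compound 3 to compound 4, 3.5-fold (0.54 log units) apart, beyond the scatter of two such steps The other change behaves in the same way, for with iodo on this carbon, amino in place of chloro gives a 1.2-fold higher number from compound 2 to compound 4 (0.08 log units; within the scatter), and the two replacements therefore do not simply add: the same change on two cores in this assay, a 4.2-fold higher number (0.62 log units; beyond the scatter) from compound 1 to compound 3 and a 1.2-fold higher number (0.08 log units; within the scatter) from compound 2 to compound 4, 3.5-fold (0.54 log units) apart, beyond the scatter of two such steps With iodo present, the read-out does not separate the amino compound from the chloro compound, a separation that it does show with chloro on this carbon.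

The compounds shown carry only chloro and iodo at this position, so it remains open whether bromo or a nitrile would follow iodo on both cores. Going by these compounds, it also remains open whether a methylamino group would match the amino group.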